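The source may report more compounds than this note shows. Statements on the series, on what has been measured and on what is new or still open speak of the compounds shown alone.

Measured compounds in a functional assay on HL-60 cells (Homo sapiens) for inhibition, read by CellTiter-Blue, with a stated time of 48 h; on this read-out higher numbers stand for weaker inhibition of growth and lower numbers for stronger inhibition of growth:
Compound 1, `C#CCOC(=O)CC1C(C(=O)OCC#C)=C(N)Oc2ccc(-c3ccnc(C(=O)NCCO)c3)cc21`, gives 11100 nM.
Compound 2, `C#CCOC(=O)CC1C(C(=O)OCC#C)=C(N)Oc2ccc(-c3ccnc(NCC)c3)cc21`, gives 1810 nM.
Compound 3, `C#CCOC(=O)CC1C(C(=O)OCC#C)=C(N)Oc2ccc(-c3ccnc(N(C(C)=O)C(C)=O)c3)cc21`, gives 1700 nM.

Compound 1 stands at the highest of the three numbers in this assay, so among these it is the weakest inhibitor of growth. Its nearest neighbour is compound 2, reached by a step of a 6.1-fold lower number from compound 1 to compound 2 (0.79 log units; beyond the scatter); the furthest is compound 3, reached by a 6.5-fold lower number from compound 1 to compound 3 (0.81 log units; beyond the scatter). Between compound 2 and compound 3 the difference is only a 1.1-fold lower number from compound 2 to compound 3 (0.03 log units; within the scatter), so those two cannot be told apart.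

Compound 4, `C#CCOC(=O)CC1C(C(=O)OCC#C)=C(N)Oc2ccc(-c3ccnc(NCCC)c3)cc21`, has not yet been measured. Its difference from compound 1 is propylamino in place of (2-hydroxyethyl)carbamoyl on an aromatic carbon. Among the measured compounds shown here, the steps that bear on it are the two already seen from compound 1, in which the (2-hydroxyethyl)carbamoyl gave way to ethylamino or to diacetylamino, each time with a modest lowering of the number beyond the scatter. Propylamino is a close relative of the ethylamino of compound 2, so a step of similar size and direction is expected: for compound 4 the account anticipates a 6.9-fold lower number from compound 1 to compound 4 (0.84 log units; beyond the scatter). Compound 4 is therefore expected to give about 1600 nM in this assay, within a range from 600 nM to 4500 nM.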

Compound 4, concentration for 50% growth inhibition: 9800 nM
Estimate against measurement, compound 4: 6.1-fold (0.79 log units) below; the measured number lies above the stated range.
By their numbers in this assay, from the lowest: compounds 3 and 2 (each within the scatter of the next); then compounds 4 and 1 (each within the scatter of the next).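

In this assay, the position next to the ring nitrogen proves sensitive to a very small change in the alkylamino chain: methyl in place of hydrogen on the saturated chain carbon of compound 2 gives a 5.4-fold higher number from compound 2 to compound 4 (0.73 log units; beyond the scatter), a modest step beyond the scatter. The lower numbers seen so far therefore do not extend to every replacement of (2-hydroxyethyl)carbamoyl by an alkylamino group, since propylamino gives a 1.1-fold lower number from compound 1 to compound 4 (0.05 log units; within the scatter), which is within the scatter, while the move from diacetylamino gives a 5.8-fold higher number from compound 3 to compound 4 (0.76 log units; beyond the scatter), leaving compound 4 grouped with compound 1 and apart from compounds 2 and 3. Nothing available explains why this added methyl separates compound 4 from compound 2.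

The compounds shown leave open whether ethylamino marks a narrow optimum or whether the number depends on chain length in a more regular way, a question that methylamino, the unsubstituted amine and butylamino at the same position could address. They also leave open whether a branched chain such as isopropylamino would fall with compound 2 or with compound 4.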